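Swapping a Methyl for Chloro in a Collagen Promoter Series

The compounds below may be only part of what the source reports. "The series", "measured", "known", "first", "only" and "open" are said of these compounds alone.

Compound 1, `CN(C)c1ccc2c(=O)c(C(=O)Nc3cc(F)cc(F)c3)cn(-c3ccc(OCCCCCCC[N+]4(C)CCCC4)c(Cl)c3)c2n1`: 2.59%
Compound 2, `CC[N+]1(CCCCCCCOc2ccc(-n3cc(C(=O)Nc4cc(F)cc(F)c4)c(=O)c4ccc(N(C)C)nc43)cc2C)CCCCC1`: 53.4%

Both compounds were tested in an assay on LX2 cells for inhibition of COL1A1 promoter (Homo sapiens), read by a luciferase reporter, with a stated time of 24 h, tested at 50 uM; a lower number here means a weaker effect, a higher number a stronger effect of the compound at the concentration tested. Compound 1 gives 2.59% there, and compound 2 gives 53.4%. Among the compounds with values here, of the two numbers measured, compound 2 stands highest; its only neighbour, compound 1, lies far enough below it for the gap to be real rather than noise. The two compounds differ in more than one place, so the data do not say which part of the structure carries that gap.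

Compound 3, `CC[N+]1(CCCCCCCOc2ccc(-n3cc(C(=O)Nc4cc(F)cc(F)c4)c(=O)c4ccc(N(C)C)nc43)cc2Cl)CCCCC1`, is not yet measured. It is obtained from compound 2 by a single change: chloro in place of methyl on an aromatic carbon. The same chloro group sits at that place in compound 1, whose value is the low one, but compound 1 also differs from compound 2 elsewhere, so the two differences cannot be separated. The expectation for compound 3 is therefore a step downward from compound 2, roughly a number 23.4 percentage points lower from compound 2 to compound 3 (beyond the scatter), with wide uncertainty around it. Compound 3 is estimated at 30%, within a range from 5% to 60%.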

Compound 3, a percentage reported as inhibition, at one concentration (the size of the read-out at that concentration, not a potency): 50.4%
Estimate against measurement, compound 3: 20.4 percentage points below; the measured number falls inside the stated range.
By their numbers in this assay, from the lowest: compound 1; then compounds 3 and 2 (each within the scatter of the next).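

In this assay, chloro in place of methyl on this aromatic carbon, ortho to a large group and meta to a large group, amounts to a number 3 percentage points lower from compound 2 to compound 3 (within the scatter) and so leaves the read-out effectively unchanged. This separates the two differences that could not be pulled apart before: compound 3 keeps the chloro of compound 1, yet the change at the far end of the chain gives a number 47.8 percentage points higher from compound 1 to compound 3 (beyond the scatter) with a group of 8 heavy atoms containing a six-membered non-aromatic ring in place of a group of 6 heavy atoms containing a five-membered non-aromatic ring. The low number of compound 1 therefore goes with that end group and not with the chloro, although no measurement at hand explains why either step has its size.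

As far as these compounds go, it remains open whether a methoxy group or a trifluoromethyl group on the same aromatic carbon would also match methyl and chloro. It is also unclear whether ring size, the alkyl group on the ring nitrogen or both account for the large step, since the two end groups differ in both respects.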